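Notes on the chloro to isopropoxy step

The compounds below may be only part of what the source reports. "The series", "measured", "known", "first", "only" and "open" are said of these compounds alone.

Values in a functional assay on A549 cells (Homo sapiens) for inhibition, read by MTT assay, with a stated time of 72 h; on this read-out higher numbers stand for weaker inhibition and lower numbers for stronger inhibition:
- compound 1 `CC(C)(C)n1cc2c(n1)C(=O)CC1(CCN(C(=O)c3cc(-c4ccc(N)cc4)nc4ccccc34)CC1)O2`: 970 nM
- compound 2 `CC(C)(C)n1cc2c(n1)C(=O)CC1(CCN(C(=O)c3cc(N4CCNCC4)nc4ccccc34)CC1)O2`: > 10000 nM (a limit of the assay)
- compound 3 `CC(C)(C)n1cc2c(n1)C(=O)CC1(CCN(C(=O)c3cc(Cl)nc4ccccc34)CC1)O2`: 7170 nM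

Of the two numeric values, the higher belongs to compound 3 at 7170 nM, and compound 1 stands lower. Compound 4 `CC(C)Oc1cc(C(=O)N2CCC3(CC2)CC(=O)c2nn(C(C)(C)C)cc2O3)c2ccccc2n1` carries isopropoxy in place of chloro on an aromatic carbon, next to the ring nitrogen: isopropoxy in place of chloro on an aromatic carbon. Among the measured compounds shown here, no measured step involves isopropoxy. The nearest evidence at this place is a 7.4-fold higher number from compound 1 to compound 3 (0.87 log units; beyond the scatter) for 4-aminophenyl and an at least 1.3-fold lower number from compound 2 to compound 3 (0.14 log units; that floor lies within the scatter) for piperazin-1-yl. Neither is a close match, so only a small step is expected in this assay, towards a lower number if any. The expected change is a 1.4-fold lower number from compound 3 to compound 4 (0.16 log units; within the scatter). Compound 4 is estimated at 5000 nM, with an expected range of 2000 nM to 12000 nM.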

Compound 4, half-maximal inhibitory concentration: > 10000 nM
Compound 4: no number, only a limit; the forecaster's own chance of this, stated with the estimate: 25%; at least 2.0-fold (0.30 log units) between middle value and limit.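

In this assay the result for compound 4 is a limit, and isopropoxy at this aromatic carbon next to the ring nitrogen stays well behind 4-aminophenyl, with an at least 10-fold higher number from compound 1 to compound 4 (1.01 log units; beyond the scatter). Against chloro there is only an at least 1.3-fold higher number from compound 3 to compound 4 (0.14 log units; that floor lies within the scatter), so this change does not separate isopropoxy from chloro. The step between compound 2 and compound 4 cannot be read because both results are limits: the limit of > 10000 nM in this assay, at which 2 of the 4 values shown sit.

The compounds shown leave open whether the aromatic ring or its amine sets compound 1 apart. A plain phenyl or a 4-hydroxyphenyl at this carbon would bear on that.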